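A few compounds are considered here, and "the series" means these few. Any claim that something is new, unique, unknown or untested is made for them only; others in the source may bear on it.

Three compounds share a core that carries a fluorine-bearing aryl ether, a quinoline-like ring system and an amide-linked bicyclic ring; they differ only at the two ends. Compound 1 `COc1cc2c(Oc3ccc(NC(=O)c4nn(-c5ccccc5F)c(=O)c5ccccc45)cc3F)ccnc2cc1OCCCN1CCN(C)CC1` gives 480 nM in a functional assay on HT-29 cells (Homo sapiens) for cytotoxicity, read by MTT assay, with a stated time of 72 h; on this read-out lower numbers stand for stronger inhibition and higher numbers for weaker inhibition. Compound 2 `COc1cc2c(Oc3ccc(NC(=O)c4nn(-c5ccc(Br)cc5)c(=O)c5ccccc45)cc3F)ccnc2cc1OCCCN1CCN(C)CC1` gives 850 nM in this assay. Compound 3 `COc1cc2c(Oc3ccc(NC(=O)c4nn(-c5ccccc5F)c(=O)c5ccccc45)cc3F)ccnc2cc1OCCCN1CCC(C)CC1` gives 510 nM in this assay.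

Compound 2 differs from compound 1 in one place, (4-bromophenyl in place of 2-fluorophenyl on an aromatic nitrogen), and that exchange made the step of a 1.8-fold higher number from compound 1 to compound 2 (0.25 log units; within the scatter). Compound 3 differs from compound 1 at the other end of the molecule, (4-methylpiperidin-1-yl in place of 4-methylpiperazin-1-yl on a saturated chain carbon, three bonds along the chain from an oxygen on an aromatic ring), and that exchange made the step of a 1.1-fold higher number from compound 1 to compound 3 (0.03 log units; within the scatter).

Compound 4 `COc1cc2c(Oc3ccc(NC(=O)c4nn(-c5ccc(Br)cc5)c(=O)c5ccccc45)cc3F)ccnc2cc1OCCCN1CCC(C)CC1` has not yet been measured. It is built from compound 3 by the change (4-bromophenyl in place of 2-fluorophenyl on an aromatic nitrogen). This is the same change that turns compound 1 into compound 2, and the surroundings of the place where it is made are described in the same words in both cases, so the two exchanges are the same change made on two cores that differ only as told above.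

Going by the values given here, because the one earlier instance of this change gave a 1.8-fold higher number from compound 1 to compound 2 (0.25 log units; within the scatter), the step from compound 3 to compound 4 is expected to be a 1.8-fold higher number from compound 3 to compound 4 (0.25 log units; within the scatter) in this assay. On that basis compound 4 is estimated to give 900 nM in this assay, with a likely range from 450 nM to 1800 nM.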

Compound 4, half-maximal inhibitory concentration: 920 nM
Compound 4: the middle estimate sits 1.0-fold (0.01 log units) below what was measured, within the range that was stated.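

In this assay, putting 4-bromophenyl in place of 2-fluorophenyl on the core of compound 3 gave a 1.8-fold higher number from compound 3 to compound 4 (0.26 log units; within the scatter), and this step agrees with the earlier one on the core of compound 1: the same change on two cores in this assay, a 1.8-fold higher number (0.25 log units; within the scatter) from compound 1 to compound 2 and a 1.8-fold higher number (0.26 log units; within the scatter) from compound 3 to compound 4, 1.0-fold (0.01 log units) apart, within the scatter of two such steps The exchange at the other end, 4-methylpiperidin-1-yl in place of 4-methylpiperazin-1-yl, now read with 4-bromophenyl in place, gave a 1.1-fold higher number from compound 2 to compound 4 (0.03 log units; within the scatter), and it too carried over from one core to the other: the same change on two cores in this assay, a 1.1-fold higher number (0.03 log units; within the scatter) from compound 1 to compound 3 and a 1.1-fold higher number (0.03 log units; within the scatter) from compound 2 to compound 4, 1.0-fold (0.01 log units) apart, within the scatter of two such steps Across these four compounds, each exchange therefore gave the same step whichever group stood at the other end, but every step lies within the usual scatter, so this does not show that either exchange really changes the read-out, and small steps that agree are only a weak test of transfer.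

On these data alone, it remains open whether the same transfer would hold for an exchange with a step beyond the scatter, such as a morpholine at the end of the chain or a longer chain. A nitrile or a methoxy group on the phenyl ring on the aromatic nitrogen would pose the same question.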